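Ethyl to Propyl on the Amide of Compound 1

The source may hold more compounds than are shown below. What is called first, only, known or untested is meant among the compounds shown, and "the series" means these compounds.

Measured compounds:
- compound 1, `CCNC(=O)c1cc(Oc2ccc(NC(=O)c3cc4cccnc4n(-c4ccc(OC)cc4)c3=O)cc2)ccn1`: 1720 nM
- compound 2, `CCNC(=O)c1cc(Oc2ccc(NC(=O)c3cc4cccnc4n(-c4ccc(C(F)(F)F)cc4Cl)c3=O)cc2)ccn1`: "not determined" (no result reported)

Two compounds were made in this set, but only compound 1 carries a number. In a functional assay on NCI-H460 cells (Homo sapiens) for antiproliferative activity, read by MTT assay, with a stated time of 72 h (on this read-out higher numbers stand for weaker inhibition and lower numbers for stronger inhibition), compound 1 gives 1720 nM. In this assay compound 2 is reported as "not determined" (no result reported), so no number can be put beside it, and nothing can be said of how the two compare. Compound 1 therefore stands alone: its value is the only one shown, and it is the sole point of reference.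

Compound 3, `CCCNC(=O)c1cc(Oc2ccc(NC(=O)c3cc4cccnc4n(-c4ccc(OC)cc4)c3=O)cc2)ccn1`, keeps the whole shared core of compound 1 and differs in one place only: methyl in place of hydrogen on a saturated chain carbon, two bonds along the chain from an amide-type nitrogen. The amide chain grows by a single carbon, from ethyl to propyl.

Within the data shown here, with no measured pair of this kind to lean on, the expectation rests on the change itself, which is small and far from the rest of the molecule. The step from compound 1 to compound 3 in this assay is expected to be a 1.0-fold lower number from compound 1 to compound 3 (0.01 log units; within the scatter), that is, nothing beyond the usual scatter. Compound 3 is therefore estimated at 1700 nM, with a likely range from 800 nM to 3600 nM.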

Compound 3, half-maximal inhibitory concentration: 1730 nM
For compound 3 the middle estimate is 1.0-fold (0.01 log units) below the measured one; low and high end bracket the measured number.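

In this assay, the move from ethyl to propyl, which puts methyl in place of hydrogen on a saturated chain carbon, two bonds along the chain from an amide-type nitrogen, comes out as a 1.0-fold higher number from compound 1 to compound 3 (0.00 log units; within the scatter) and so stays level with the starting compound. Among these compounds, until now compound 1 stood as a single point with nothing to compare it with, whereas this pair gives the first measured look at this position and shows that one more carbon on the amide chain does not move the antiproliferative read-out beyond the usual scatter. No measurement at hand says why the read-out stays put here.

One small step on one chain says little about how far this position can be changed, so a longer chain such as butyl, a branched group such as isopropyl, or a chain ending in an amine or a carboxylic acid could behave quite differently. Going by these compounds, it also remains open whether the same ethyl to propyl change would stay as quiet on a compound with other groups elsewhere on the shared core.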